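Phenol for Methoxypyridine on a Dopamine Transporter Series

This account rests on a few compounds, and the source may have more. Where it says the series, first, only, none or still open, it means among the compounds named here.

Three compounds with a shared core were tested in an assay on striatum for inhibition of sodium-dependent dopamine transporter (Rattus norvegicus); a higher number here means a weaker inhibitor, a lower number a stronger inhibitor. Compound 1 `O[C@@H]1C[C@@H](C(c2ccc(F)cc2)c2ccc(F)cc2)OC[C@H]1NCc1ccc2c(c1)CCO2` gives 17 nM. Compound 2 `COc1ccc(CN[C@@H]2CO[C@H](C(c3ccccc3)c3ccccc3)C[C@H]2O)cn1` gives 44.1 nM, the second highest of the three numbers. Compound 3 `c1ccc(C(c2ccccc2)[C@@H]2CC[C@H](NCc3ccc4occc4c3)CO2)cc1` gives 81.9 nM, which lies within the usual scatter of compound 2, while compound 1 sits beyond the scatter with the lower number. Compound 4 `COc1cc(O)cc(CN[C@@H]2CO[C@H](C(c3ccccc3)c3ccccc3)C[C@H]2O)c1` is not yet measured; it differs from compound 2 by 3-hydroxy-5-methoxyphenyl in place of 6-methoxypyridin-3-yl on a saturated chain carbon bound to an amine nitrogen. For the measured compounds named here, no measured pair matches this change, so the expectation rests on compound 2 alone: the step of a 1.1-fold higher number from compound 2 to compound 4 (0.05 log units; within the scatter) is expected to stay within the scatter, in no firm direction. Compound 4 is therefore estimated at 50 nM, with a range from 20 nM to 130 nM.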

Compound 4, inhibition constant: 209 nM
Compound 4: the middle estimate sits 4.2-fold (0.62 log units) below what was measured; measured number outside the range, above it.
By their numbers in this assay, from the lowest: compound 1; then compounds 2 and 3 (each within the scatter of the next); then compound 4.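

In this assay, 3-hydroxy-5-methoxyphenyl in place of 6-methoxypyridin-3-yl gives a 4.7-fold higher number from compound 2 to compound 4 (0.68 log units; beyond the scatter). For the compounds shown here, this is the first single-place comparison, and it shows that the number responds to which aromatic group sits on this saturated chain carbon bound to an amine nitrogen. Nothing available accounts for the weaker binding.

The ring nitrogen, the hydroxy group and the methoxy placement all change together, so their shares remain unseparated. As far as these compounds go, how a 3-methoxyphenyl or 3,5-dimethoxyphenyl group would compare at this place remains open.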